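Replacing the Bromophenyl Amide of Compound 2

The compounds below may be only part of what the source reports. "The series", "measured", "known", "first", "only" and "open" are said of these compounds alone.

Within the data shown here, compound 2 (`O=C(/C=C/c1cccc(NC(=O)c2ccccc2Br)c1)c1nc2ccccc2[nH]1`) gives 1680 nM in a functional assay on HCT-116 cells (Homo sapiens) for antiproliferative activity, read by MTT assay, with a stated time of 48 h (on this read-out lower numbers stand for stronger inhibition and higher numbers for weaker inhibition), the lowest of the two numbers measured so far; its nearest neighbour, compound 1 (`O=C(Nc1cccc(/C=C/C(=O)c2nc3ccccc3[nH]2)c1)c1ccccc1`), gives 2440 nM in this assay. Among the measured compounds shown here, the single step measured so far, a 1.5-fold lower number from compound 1 to compound 2 (0.16 log units; within the scatter), lies within the scatter. Compound 3 (`O=C(Nc1cccc(/C=C/C(=O)c2nc3ccccc3[nH]2)c1)c1cc(Cl)cc(Cl)c1`) differs from compound 2 in one place: 3,5-dichlorophenyl in place of 2-bromophenyl on a carbonyl carbon. For the measured compounds named here, no measured step covers this exchange directly; the only step that touches the same ring, a 1.5-fold lower number from compound 1 to compound 2 (0.16 log units; within the scatter), put bromo in place of hydrogen on an aromatic carbon and stayed within the scatter, so nothing in these data points to a large shift in this assay. Compound 3 is therefore expected to show a step of a 1.1-fold lower number from compound 2 to compound 3 (0.05 log units; within the scatter). The estimated value for compound 3 in this assay is 1500 nM, with a range of 600 nM to 4000 nM.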

Compound 3, half-maximal inhibitory concentration: 1650 nM
The estimate for compound 3 lay 1.1-fold (0.04 log units) below the measured number, within the range that was stated.
By their numbers in this assay, from the lowest: compounds 3, 2 and 1 (each within the scatter of the next).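

Read in this assay, the step of a 1.0-fold lower number from compound 2 to compound 3 (0.01 log units; within the scatter) and the step of a 1.5-fold lower number from compound 1 to compound 3 (0.17 log units; within the scatter) both stay within the scatter, so phenyl, 2-bromophenyl and 3,5-dichlorophenyl on this carbonyl carbon cannot be told apart. Compound 3 extends what the single bromo step showed: a ring with two chlorine atoms in place of one bromine or of none still leaves the number where it was, and the position has so far shown no sensitivity to which halogens the ring carries. Nothing at hand explains why these numbers stay together.

The compounds shown leave open whether a ring carrying an amine or a carboxylic acid, or a longer alkyl chain in place of the ring, would move the number beyond the scatter. They also leave open whether any group at this position separates from the others in this assay.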